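The source may hold more compounds than are shown below. What is called first, only, known or untested is meant among the compounds shown, and "the series" means these compounds.

Measured compounds:

Compound 1, `COc1ccc(-c2cc(/C=C/C(=O)c3ccc(N)cc3)[nH]n2)cc1`: in a functional assay on NCI/ADR-RES cells (Homo sapiens) for cytotoxicity, read by sulforhodamine B assay, with a stated time of 48 h, tested at 100 uM (on this read-out higher numbers stand for a weaker effect at the one concentration tested and lower numbers for a stronger effect), compound 1 gives -38%.

Compound 2, `COc1ccc(C(=O)/C=C/c2cc(-c3cc(OC)c(OC)c(OC)c3)n[nH]2)cc1`: in this assay compound 2 gives -6%.

Of these two numbers, compound 1 holds the lowest, which on this read-out means the stronger effect at the single concentration tested. The nearest number is that of compound 2, which lies higher by a gap beyond the usual scatter of repeated measurements. Compound 2 differs from compound 1 in more than one place, so its number says only where the two stand, not what any single change does.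

Compound 3, `COc1ccc(-c2cc(/C=C/C(=O)c3ccc(N)cc3)[nH]n2)cc1OC`, has not been measured. It differs from compound 1 in one place: methoxy in place of hydrogen on an aromatic carbon. Among the compounds with values here, no measured pair shows what such a change does here, so the expectation rests on compound 1 alone. A change of this small size is expected to move the number little, in either direction, most likely staying within the scatter of compound 1. The expected step from compound 1 to compound 3 is a number 8 percentage points higher from compound 1 to compound 3 (within the scatter). Compound 3 is therefore estimated at -30%, within a range from -65% to 10%.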

Compound 3, a percentage reported as activity, at one concentration (the size of the read-out at that concentration, not a potency): 2%
Estimate against measurement, compound 3: 32 percentage points below, within the range that was stated.
By their numbers in this assay, from the lowest: compound 1; then compounds 2 and 3 (each within the scatter of the next).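

In this assay, within the data shown here, placing a methoxy group on the aromatic carbon ortho to a methoxy group gives a number 40 percentage points higher from compound 1 to compound 3 (beyond the scatter), and this is the first single change that can be read. Since a higher number means a weaker effect, this position is not indifferent to substitution: a group of just 2 heavy atoms in place of hydrogen takes away much of the effect of compound 1, leaving compound 3 at 2%. Nothing available explains why this change weakens the effect.

The compounds shown do not reveal whether this loss is specific to methoxy or would follow any group placed here, and a hydroxy group, a fluorine atom or a longer ethoxy chain at the same carbon would help to separate those possibilities. Going by these compounds, it also remains open whether methoxy in place of hydrogen would give a step of similar size at other aromatic carbons of the core, so this result describes one position and one change only.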